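This account rests on a few compounds, and the source may have more. Where it says the series, first, only, none or still open, it means among the compounds named here.

In a functional assay on A549 cells (Homo sapiens) for antiproliferative activity, read by MTT assay, with a stated time of 72 h (a higher number here means a weaker inhibitor, a lower number a stronger inhibitor), compound 1 `O=C(CCCCCCc1nc(-c2ccc(C(F)(F)F)cc2)no1)NO` gives 14000 nM and compound 2 `COc1ccc(-c2noc(CCCCCCC(=O)C(F)(F)F)n2)cc1` gives 35900 nM, the higher of the two numbers and a gap beyond the usual scatter. Compound 3 `O=C(CCCCCCc1nc(-c2ccc(C(F)(F)F)cc2)no1)C(F)(F)F` has trifluoromethyl in place of methoxy on an aromatic carbon. For the measured compounds named here, compound 1 carries trifluoromethyl too, but it also differs from compound 2 elsewhere, so no measured pair isolates this change. In this assay, a small shift toward a lower number is expected, probably within the scatter. The expected step of a 1.3-fold lower number from compound 2 to compound 3 (0.11 log units; within the scatter) is therefore modest. Compound 3 is estimated at 28000 nM, with an expected range of 11000 nM to 60000 nM.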

Compound 3, half-maximal inhibitory concentration: 28800 nM
For compound 3 the middle estimate is 1.0-fold (0.01 log units) below the measured one, within the range that was stated.
By their numbers in this assay, from the lowest: compound 1; then compounds 3 and 2 (each within the scatter of the next).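

In this assay, trifluoromethyl in place of methoxy on an aromatic carbon gives a 1.2-fold lower number from compound 2 to compound 3 (0.10 log units; within the scatter), so this change at this position cannot be told apart from the usual scatter. The other end of the molecule can now be read alone: trifluoromethyl in place of hydroxyamino on a carbonyl carbon gives a 2.1-fold higher number from compound 1 to compound 3 (0.31 log units; beyond the scatter), a modest loss of activity. Nothing available accounts for either step.

Still open, from the compounds shown here alone, is whether an amine on that aromatic carbon would shift the number beyond the scatter, and whether a carboxylic acid on the carbonyl carbon would hold the activity seen with hydroxyamino.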